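Swapping a pyridyl ethyl thioether for a cumyl thioether

The source may report more compounds than this note shows. Statements on the series, on what has been measured and on what is new or still open speak of the compounds shown alone.

Of the compounds shown here, three sharing one core have been measured in an assay on isolated protein for inhibition of aldehyde dehydrogenase 1A1 (Homo sapiens); on this read-out higher numbers stand for weaker inhibition and lower numbers for stronger inhibition. Compound 1, with the structure `CC(Sc1nc2c(cnn2C)c(=O)n1-c1ccccc1)c1ccccn1`, gives 242 nM, the lowest of the three numbers. Compound 3, `Cn1ncc2c(=O)n(-c3ccccc3)c(/C=C/c3cccc(F)c3)nc21`, gives 270 nM, which sits within the usual scatter of compound 1 and so cannot be ranked against it. Compound 2, `CC(Oc1nc2c(cnn2C)c(=O)n1-c1ccccc1)c1ccccc1`, gives 2400 nM, a number clearly beyond the scatter of compound 1 and thus a weaker inhibitor.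

The next compound, compound 4, has the structure `Cn1ncc2c(=O)n(-c3ccccc3)c(SC(C)(C)c3ccccc3)nc21` and has not yet been tested in this assay. It differs from compound 1 in a single place: 1-methyl-1-phenylethyl in place of 1-(pyridin-2-yl)ethyl on a sulfur. For the measured compounds named here, compound 2, which also carries a carbon-only ring on its side chain though joined through oxygen rather than sulfur, gives the weakest number seen so far, so some loss is plausible, but no directly comparable step has been measured. The expected step toward weaker inhibition is a 2.3-fold higher number from compound 1 to compound 4 (0.36 log units; beyond the scatter). The estimate for compound 4 in this assay is 550 nM, with a likely range from 150 nM to 2000 nM.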

Compound 4, half-maximal inhibitory concentration: 1900 nM
Estimate against measurement, compound 4: 3.5-fold (0.54 log units) below, within the range that was stated.
By their numbers in this assay, from the lowest: compounds 1 and 3 (each within the scatter of the next); then compounds 4 and 2 (each within the scatter of the next).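

For the compounds shown here, on the sulfur of the shared core, 1-methyl-1-phenylethyl in place of 1-(pyridin-2-yl)ethyl gives a 7.9-fold higher number from compound 1 to compound 4 (0.89 log units; beyond the scatter) in this assay, the first direct comparison at this position, and it shows that inhibition is sensitive to the group held there. This one step alters two things at once: the aromatic ring loses its nitrogen and the chain gains a methyl, so the result cannot assign the weaker inhibition to either alteration. Nothing measured on these compounds explains the loss.

Open, going by these compounds, is how 1-phenylethyl or 1-methyl-1-(pyridin-2-yl)ethyl on the same sulfur would read, since each would carry only one of the two alterations. Also open, on these data alone, is how the number would respond to an amine or a carboxylic acid on this side chain.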